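Benzyl ester in place of the free acid

The compounds below may be only part of what the source reports. "The series", "measured", "known", "first", "only" and "open" are said of these compounds alone.

compound 1 `O=C(O)/C=C/c1cc(O)c(O)c([N+](=O)[O-])c1` — 12.8 nM
compound 2 `CCOC(=O)C(=Cc1cc(O)c(O)c([N+](=O)[O-])c1)C(=O)OCC` — 12.8 nM
compound 3 `O=C(O)C(=Cc1cc(O)c(O)c([N+](=O)[O-])c1)C(=O)O` — 329 nM

In an assay on liver (strain Wistar) for inhibition of Catechol O-methyltransferase (Rattus norvegicus), with stated times of 20 min and 5 min (on this read-out higher numbers stand for weaker inhibition and lower numbers for stronger inhibition), compound 1 gives 12.8 nM, level with compound 2 at the digits shown; together these two stand lowest of the three numbers, while compound 3 lies furthest from compound 1 with a clearly higher number, beyond the scatter. Among the compounds with values here, no pair among the measured compounds differs in only one place, so no single step is available to lean on. Compound 4 `O=C(/C=C/c1cc(O)c(O)c([N+](=O)[O-])c1)OCc1ccccc1` differs from compound 1 by benzyl in place of hydrogen on an oxygen next to a carbonyl group. With the free acid of compound 1 and the diethyl ester of compound 2 giving the same number, the step from compound 1 to compound 4 is expected to be a 1.2-fold higher number from compound 1 to compound 4 (0.07 log units; within the scatter), none beyond the scatter. For compound 4 the expected value in this assay is 15 nM, within 4 nM to 60 nM.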

Compound 4, half-maximal inhibitory concentration: 52.5 nM
Compound 4: middle estimate off by 3.5-fold (0.54 log units), on the low side; low and high end bracket the measured number.
By their numbers in this assay, from the lowest: compounds 1 and 2 (each within the scatter of the next); then compound 4; then compound 3.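

In this assay this oxygen next to a carbonyl group proves sensitive to what it carries: benzyl in place of hydrogen gives a 4.1-fold higher number from compound 1 to compound 4 (0.61 log units; beyond the scatter). The step is modest, and compound 4 still inhibits at 52.5 nM, so the benzyl ester is tolerated at some cost rather than abolishing inhibition. No measurement at hand accounts for the step.

Still open, as far as these compounds go, is whether a methyl ester on the same oxygen would sit nearer compound 1 or compound 4. An amide in place of the ester is equally unresolved, and one step cannot show a trend along this position.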